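The compounds below may be only part of what the source reports. "The series", "measured", "known", "first", "only" and "open" are said of these compounds alone.

Measured compounds:
compound 1, `NC1=NC2(CCOCC2)N(OCCCOc2cccc(Cl)c2)C(N)=N1` — "not determined" (no result reported) (no number reported)
compound 2, `NC1=NC2(CCOCC2)N(OCCCOc2ccccc2Br)C(N)=N1` — "not determined" (no result reported) (no number reported)
compound 3, `CC(C)(C)c1ccc(OCCCON2C(N)=NC(N)=NC23CCOCC3)cc1` — 3.72 nM

In an assay on isolated protein for inhibition of Dihydrofolate reductase (Homo sapiens), read by spectrophotometry, using NADPH, with stated times of 5 s and 6 min (on this read-out lower numbers stand for stronger inhibition and higher numbers for weaker inhibition), compound 3 gives 3.72 nM, and this is the only number shown in the set. Compound 1 and compound 2 carry no result in this assay, so compound 3 cannot be ranked against them; it simply stands alone as the one measured point.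

Compound 4, `NC1=NC2(CCOCC2)N(OCCCOc2ccccc2)C(N)=N1`, has not yet been measured in this assay. It differs from compound 3 in one place: hydrogen in place of tert-butyl on an aromatic carbon. The tert-butyl group on the aromatic carbon of the six-membered aromatic ring of carbon only, para to a large group, is replaced by a hydrogen atom, and nothing else in the molecule changes.

For the measured compounds named here, no step between two measured compounds is available to calibrate this change, so the expectation rests on the single value of compound 3 and on the nature of the change. Removing a group of four carbon atoms and putting in only hydrogen is expected to cost some potency, with a step of a 3.2-fold higher number from compound 3 to compound 4 (0.51 log units; beyond the scatter) that is expected to go somewhat beyond the usual scatter toward weaker inhibition. Compound 4 is therefore estimated at 12 nM, with a plausible range from 3 nM to 50 nM.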

Compound 4, half-maximal inhibitory concentration: 86.1 nM
Estimate against measurement, compound 4: 7.2-fold (0.86 log units) below, and the stated range ends below it.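

In this assay, the exchange of tert-butyl for hydrogen on an aromatic carbon, para to a large group, gives a 23-fold higher number from compound 3 to compound 4 (1.36 log units; beyond the scatter). The earlier compounds shown here offered a single number and no step, whereas this pair shows that the position matters a great deal in this assay, since only this one place differs between the two structures. The change does not abolish inhibition, as compound 4 still reads 86.1 nM, so the tert-butyl group adds strongly to a level of inhibition that is already measurable without it. Nothing in the data at hand bears on the reason for this step.

The two numbers leave open how the read-out would respond to a methyl, an isopropyl, a methoxy, an amine or a carboxylic acid at the same place, and so whether the response rises gradually from hydrogen to tert-butyl or is specific to tert-butyl. They also leave open whether the exchange would give a step of similar size with a longer chain linking the aromatic ring to the shared core.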